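The source may hold more compounds than are shown below. What is called first, only, known or untested is meant among the compounds shown, and "the series" means these compounds.

Measured compounds:
compound 1 `COc1ccc(C2=C(c3ccccc3)C(=O)N3CCCC3C2)cc1` gives 390 nM in a functional assay on HCT-116 cells (Homo sapiens) for cytotoxicity; on this read-out lower numbers stand for stronger inhibition and higher numbers for weaker inhibition;
compound 2 `COc1ccc(C2=C(c3cccnc3)C(=O)N3CCCC3C2)cc1` gives 79000 nM in this assay.

Within the data shown here, compound 2 stands at the highest number of the two, so it is the weaker inhibitor in this assay, and its only neighbour is compound 1, which sits a long way lower. Among the measured compounds shown here, the one measured step between them, a 200-fold higher number from compound 1 to compound 2 (2.31 log units; beyond the scatter), shows how much swapping the ring on that double-bonded ring carbon can move the read-out.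

Compound 3 `COc1ccc(C2=C(c3cccs3)C(=O)N3CCCC3C2)cc1` differs from compound 2 in a single place: thiophen-2-yl in place of pyridin-3-yl on a double-bonded ring carbon. For the measured compounds named here, no measured step covers this particular exchange, so the only guide is the step from compound 1 to compound 2, which was large. Because the step of a 200-fold higher number from compound 1 to compound 2 (2.31 log units; beyond the scatter) came from replacing phenyl with pyridin-3-yl, and compound 3 now removes that pyridin-3-yl again, a move back toward lower numbers is expected, though not necessarily all the way to compound 1. The step from compound 2 to compound 3 is therefore estimated as a 66-fold lower number from compound 2 to compound 3 (1.82 log units; beyond the scatter). For compound 3 the expected value in this assay is 1200 nM, with a range from 250 nM to 8000 nM.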

Compound 3, half-maximal inhibitory concentration: 5000 nM
Beside the measured number, compound 3's estimate is 4.2-fold (0.62 log units) below it; the range from low to high includes it.
By their numbers in this assay, from the lowest: compound 1; then compound 3; then compound 2.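

Adding a third ring on this double-bonded ring carbon shows that the read-out in this assay does not simply flip between a good and a bad group: thiophen-2-yl in place of pyridin-3-yl gives a 16-fold lower number from compound 2 to compound 3 (1.20 log units; beyond the scatter), while thiophen-2-yl in place of phenyl gives a 13-fold higher number from compound 1 to compound 3 (1.11 log units; beyond the scatter), so the new compound sits clearly between the other two. Pyridin-3-yl and thiophen-2-yl each have one hetero atom in the ring and one hydrogen-bond acceptor, yet they are still far apart, so these counts alone do not predict the number at this position. Nothing measured here explains why the three rings fall in this order.

From the compounds shown here alone, it remains open whether phenyl is the best of the possible groups here, or whether a substituted ring, such as a phenyl bearing an amine or a carboxylic acid, would move the number further in either direction. Going by these compounds, it is also open whether a ring is needed at all, which a longer chain such as n-butyl in its place could test, and whether furan-2-yl would land close to thiophen-2-yl.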